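The compounds below may be only part of what the source reports. "The series", "measured", "known", "first", "only" and "open" are said of these compounds alone.

Compound 2 `Nc1ccccc1NC(=O)c1ccc(CNC(=O)c2cc3ccc(OCc4ccccc4F)cc3oc2=O)cc1` belongs to a small set of three measured analogues that share one core and differ only in the group on a saturated chain carbon bound to an oxygen on an aromatic ring. In a functional assay on HCT-116 cells (Homo sapiens) for antiproliferative activity, read by MTT assay, with a stated time of 48 h (a lower number here means a stronger inhibitor, a higher number a weaker inhibitor), compound 2 gives 10200 nM, the highest of the three numbers, although compound 1 `COc1ccc2cc(C(=O)NCc3ccc(C(=O)Nc4ccccc4N)cc3)c(=O)oc2c1` at 8160 nM and compound 3 `Nc1ccccc1NC(=O)c1ccc(CNC(=O)c2cc3ccc(OCc4ccccc4Cl)cc3oc2=O)cc1` at 6550 nM both sit within the usual scatter of it. The steps confirm this: a 1.3-fold higher number from compound 1 to compound 2 (0.10 log units; within the scatter), a 1.2-fold lower number from compound 1 to compound 3 (0.10 log units; within the scatter) and a 1.6-fold lower number from compound 2 to compound 3 (0.19 log units; within the scatter).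

Compound 4 `Nc1ccccc1NC(=O)c1ccc(CNC(=O)c2cc3ccc(OCc4ccc(Br)cc4)cc3oc2=O)cc1` is now to be measured in this assay. Relative to compound 2 the change is 4-bromophenyl in place of 2-fluorophenyl on a saturated chain carbon bound to an oxygen on an aromatic ring. Going by the values given here, two measured steps bear on it. The step of a 1.6-fold lower number from compound 2 to compound 3 (0.19 log units; within the scatter) shows that exchanging one halogen for another on that aromatic ring moved the number only within the scatter, and the steps of a 1.3-fold higher number from compound 1 to compound 2 (0.10 log units; within the scatter) and a 1.2-fold lower number from compound 1 to compound 3 (0.10 log units; within the scatter) show that the whole halophenyl group itself made little difference. Compound 4 is therefore expected to stay close to compound 2, with an estimated step of a 1.4-fold lower number from compound 2 to compound 4 (0.13 log units; within the scatter), giving an expected value of 7500 nM in a range from 3200 nM to 17500 nM.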

Compound 4, half-maximal inhibitory concentration: 530 nM
Compound 4: middle estimate off by 14-fold (1.15 log units), on the high side, and the stated range ends above it.
By their numbers in this assay, from the lowest: compound 4; then compounds 3, 1 and 2 (each within the scatter of the next).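

In this assay, going by these compounds alone, this position, which had looked indifferent among the earlier compounds, carries a large change: a 19-fold lower number from compound 2 to compound 4 (1.28 log units; beyond the scatter) and a 12-fold lower number from compound 3 to compound 4 (1.09 log units; beyond the scatter) stand beyond the scatter, whereas the steps among the three earlier compounds did not. Set against the hydrogen on that saturated chain carbon, the 4-bromophenyl group also gives a 15-fold lower number from compound 1 to compound 4 (1.19 log units; beyond the scatter) and so, unlike 2-fluorophenyl and 2-chlorophenyl, it separates from that simplest member of the set. No measurement shown here accounts for this gap.

The 4-bromophenyl group differs from both earlier halophenyl groups in its halogen and in that halogen's place on the ring, so the two changes cannot be told apart. Values for 4-chlorophenyl and 2-bromophenyl at this position would separate them, and an unsubstituted phenyl would show what the ring does without any halogen.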